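Swapping phenyl for thiophen-2-yl on a shared core

The compounds below may be only part of what the source reports. "The series", "measured", "known", "first", "only" and "open" are said of these compounds alone.

Measured so far:
- Compound 1 `N#CC1=C(N)N(c2ccc(S(N)(=O)=O)cc2)C2=C(C(=O)CCC2)C1c1ccccc1`: 40%
- Compound 2 `N#CC1=C(N)N(c2ccc(S(N)(=O)=O)cc2)C2=C(C(=O)CCC2)C1c1c(O)ccc2ccccc12`: 5%

In a functional assay on Ehrlich cells (Mus musculus) for antiproliferative activity, read by trypan blue exclusion, with a stated time of 2 h, tested at 50 ug/mL (a higher number here means a stronger effect of the compound at the concentration tested, a lower number a weaker effect), compound 1 gives the highest of the two numbers; compound 2 sits a step of a number 35 percentage points lower from compound 1 to compound 2 (beyond the scatter) below it. Compound 3 `N#CC1=C(N)N(c2ccc(S(N)(=O)=O)cc2)C2=C(C(=O)CCC2)C1c1cccs1` differs from compound 1 by thiophen-2-yl in place of phenyl on a saturated ring carbon. For the measured compounds named here, the only measured step, from compound 1 to compound 2, concerns a different, larger group, so it bears on this change only loosely. With no closer comparison, a step within the scatter is expected: a number 5 percentage points lower from compound 1 to compound 3 (within the scatter). Compound 3 is therefore estimated at 35%, between 15% and 55%.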

Compound 3, a percentage reported as activity, at one concentration (the size of the read-out at that concentration, not a potency): 88%
Compound 3: middle estimate off by 53 percentage points, on the low side, outside the stated range (above it).
By their numbers in this assay, from the lowest: compound 2; then compound 1; then compound 3.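

In this assay, the group on this saturated ring carbon can raise the read-out as well as lower it: thiophen-2-yl gives a number 48 percentage points higher from compound 1 to compound 3 (beyond the scatter) and a number 83 percentage points higher from compound 2 to compound 3 (beyond the scatter). The earlier pair showed only a loss here, whereas exchanging phenyl for a five-membered aromatic ring with one sulfur brings a large gain. Nothing available explains this gain.

On these data alone, it remains open whether the gain depends on the sulfur or on the five-membered ring. Furan-2-yl, which has oxygen in place of that sulfur, would help separate the two.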